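Truncating the chain terminus: compound 3 to compound 4

The source may report more compounds than this note shows. Statements on the series, on what has been measured and on what is new or still open speak of the compounds shown alone.

Three compounds share one core and differ at the far end of the thioalkyl chain. Compound 1 `Cn1c(Cc2nn(C)c(=O)c3ccccc23)nnc1SCCCCCCCC(=O)Nc1ccc(F)cc1F` in an assay on isolated protein (Mus musculus) for inhibition of IL15-IL15 receptor (Homo sapiens), read by resazurin assay, with stated times of 30 min and 2.5 days (a higher number here means a weaker inhibitor, a lower number a stronger inhibitor), gives 2300 nM. Compound 2 `COc1ccc(NC(=O)CCCCCCCSc2nnc(Cc3nn(C)c(=O)c4ccccc34)n2C)cc1` gives 3900 nM in this assay. Compound 3 `Cn1c(Cc2nn(C)c(=O)c3ccccc23)nnc1SCCCCCCCCCCC(=O)Oc1ccc(Cl)cc1Cl` gives 8700 nM in this assay and so stands highest of the three numbers; compound 2 is nearest to it and compound 1 furthest, both beyond the scatter.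

Compound 4 `CCCCCCCCCCSc1nnc(Cc2nn(C)c(=O)c3ccccc23)n1C` is obtained from compound 3 by the change (hydrogen in place of (2,4-dichlorophenoxy)carbonyl on a saturated chain carbon, ten or more bonds along the chain from a sulfur). Among the measured compounds shown here, the only measured single-point step, a 1.7-fold higher number from compound 1 to compound 2 (0.23 log units; within the scatter), swaps one terminal aryl for another at the amide end and does not reach beyond the scatter; it bears on compound 4 only loosely, as it keeps the terminal group while compound 4 loses it. For the measured compounds named here, no measured step removes the terminus entirely, so the direction in this assay is open; a moderate rise in the number is the working expectation. Compound 4 is therefore estimated at 12000 nM, in a range from 4000 nM to 40000 nM. The expected step is a 1.4-fold higher number from compound 3 to compound 4 (0.14 log units; within the scatter).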

Compound 4, half-maximal inhibitory concentration: 7600 nM
Estimate against measurement, compound 4: 1.6-fold (0.20 log units) above; low and high end bracket the measured number.
By their numbers in this assay, from the lowest: compounds 1, 2, 4 and 3 (each within the scatter of the next, the first and the last beyond it).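

In this assay, the loss of the (2,4-dichlorophenoxy)carbonyl group, with its 11 heavy atoms and aromatic ring, leaves the number unchanged within the scatter (a 1.1-fold lower number from compound 3 to compound 4 (0.06 log units; within the scatter)), so this terminus is not required for activity at this level. The unsubstituted chain of compound 4 also stays within the scatter of the anilide compound 2 (a 1.9-fold higher number from compound 2 to compound 4 (0.29 log units; within the scatter)), and only the terminus of compound 1 shows a modest edge beyond it (a 3.3-fold higher number from compound 1 to compound 4 (0.52 log units; beyond the scatter)), so an amide terminus does not consistently separate from the bare chain. No available evidence bears on the reason for this result.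

From the compounds shown here alone, whether a carboxylic acid or an amine at the chain end would move the number remains open. Also open, going by these compounds, is whether a shorter chain without a terminal group would hold it.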